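Swapping tert-butyl for cyclohexyl on the aryl amide

This account rests on a few compounds, and the source may have more. Where it says the series, first, only, none or still open, it means among the compounds named here.

Of the compounds shown here, three in this set share one core and have been measured in an assay on HEK293 cells for displacement of a labelled ligand from NPC1-like intracellular cholesterol transporter 1 (Homo sapiens); a lower number here means a stronger inhibitor, a higher number a weaker inhibitor. Compound 1 `O=C(CN1CN(c2ccccc2)C2(CCN(C(=O)c3ccc(C4CCCCC4)cc3)CC2)C1=O)N1CCC(CO)CC1` gives 1100 nM. Compound 2 `CS(=O)(=O)NCCNC(=O)CN1CN(c2ccccc2)C2(CCN(C(=O)c3ccc(C4CCCCC4)cc3)CC2)C1=O` gives 2100 nM. Compound 3 `CC(C)(C)OC(=O)NCCCNC(=O)CN1CN(c2ccccc2)C2(CCN(C(=O)c3ccc(C(C)(C)C)cc3)CC2)C1=O` gives 4500 nM, the highest of the three numbers; its gap to compound 2 and its gap to compound 1 both lie beyond the scatter. For the measured compounds named here, the only measured step, a 1.9-fold higher number from compound 1 to compound 2 (0.28 log units; within the scatter), changes the group on the carbonyl carbon and stays within the scatter.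

Compound 4 `CC(C)(C)OC(=O)NCCCNC(=O)CN1CN(c2ccccc2)C2(CCN(C(=O)c3ccc(C4CCCCC4)cc3)CC2)C1=O` differs from compound 3 in one place: cyclohexyl in place of tert-butyl on an aromatic carbon. Going by the values given here, no measured pair changes this group alone, so no step bears directly on it. Compound 1 and compound 2 both carry cyclohexyl and give lower numbers than compound 3, yet their side chains also differ, so the comparison is indirect. A modest downward step, a 1.8-fold lower number from compound 3 to compound 4 (0.26 log units; within the scatter), is expected. Compound 4 is therefore estimated at 2500 nM, with a range from 1000 nM to 6000 nM.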

Compound 4, half-maximal inhibitory concentration: 6000 nM
For compound 4 the middle estimate is 2.4-fold (0.38 log units) below the measured one; the measured number falls inside the stated range.
By their numbers in this assay, from the lowest: compounds 1 and 2 (each within the scatter of the next); then compounds 3 and 4 (each within the scatter of the next).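

In this assay, for the compounds shown here, this is the first direct test of the swap on the aryl amide (a 1.3-fold higher number from compound 3 to compound 4 (0.12 log units; within the scatter)), and with this side chain the 4-(tert-butyl)phenyl and 4-cyclohexylphenyl versions cannot be told apart. With cyclohexyl held constant, the larger differences follow the side chain, both beyond the scatter (a 2.9-fold higher number from compound 2 to compound 4 (0.46 log units; beyond the scatter); a 5.5-fold higher number from compound 1 to compound 4 (0.74 log units; beyond the scatter)). No measurement shown here offers an explanation for these results.

From the compounds shown here alone, it remains open whether cyclohexyl and tert-butyl would also match when paired with the 4-(hydroxymethyl)piperidin-1-yl group of compound 1. Also unsettled is how a phenyl or trifluoromethyl group on the same aromatic carbon, or a free amine in place of the tert-butoxycarbonyl-protected amine at the end of the chain, would read in this assay.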